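From compound 1 to compound 4: hydrogen for ethoxy

The source may hold more compounds than are shown below. What is called first, only, known or untested is meant among the compounds shown, and "the series" means these compounds.

Measured in a functional assay on MCF7 cells (Homo sapiens) for inhibition, read by MTT assay, with a stated time of 24 h; on this read-out lower numbers stand for stronger inhibition and higher numbers for weaker inhibition:
- compound 1 `CCOC1c2cc(OCc3cc(C)cc(C)c3)c(OCc3cc(C)cc(C)c3)cc2CCN1C(=O)OC(C)(C)C`: > 20000 nM (a limit)
- compound 2 `CCC[C@@H]1C[C@@H](O)/C=C\C(CC)[C@H]2c3cc(OCc4ccccc4)c(OCc4ccccc4)cc3CCN12`: "not determined" (no result reported)
- compound 3 `CC[C@@H]1C[C@@H](O)C/C=C(/C)[C@H]2c3cc(OCc4ccccc4)c(OCc4ccccc4)cc3CCN12`: > 20000 nM (a limit)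

Compound 1 has no exact value in this assay: its > 20000 nM is a limit and not a number. Compound 2 gives no result to compare with it. Across the series the record shows (the limit of > 20000 nM in this assay, at which 2 of the 3 values shown sit). Going by the values given here, no pair of measured compounds differing in one place is available, so the data hold no direct reading of any single change.

Compound 4 `Cc1cc(C)cc(COc2cc3c(cc2OCc2cc(C)cc(C)c2)CN(C(=O)OC(C)(C)C)CC3)c1` is the next compound to be read, and it departs from compound 1 in one place: hydrogen in place of ethoxy on a saturated ring carbon. In words, this is hydrogen in place of ethoxy on a saturated ring carbon, with the rest of the core of compound 1 and both aryl ether groups unchanged.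

No step beyond the scatter is expected in this assay, in either direction. This expectation rests on compound 1, whose reading is the limit > 20000 nM. The expected change is small, and the estimated step is a step that the limit leaves unreadable from compound 1 to compound 4. The most likely report is another limit. For compound 4 the estimated value is 25000 nM, with an expected range of 10000 nM to 60000 nM.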

Compound 4, half-maximal inhibitory concentration: > 20000 nM
Compound 4 was reported as a limit; the forecaster's own chance of this, stated with the estimate: 75%; the middle value lies beyond the limit too.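

In this assay compound 4 gives > 20000 nM, which is a limit and not a number. Compound 1 also stands at a limit, so no step between compound 1 and compound 4 can be read: the limit of > 20000 nM in this assay, at which 3 of the 4 values shown sit.

The compounds shown leave open whether hydrogen in place of ethoxy on a saturated ring carbon alters inhibition in this assay.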